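A few compounds are considered here, and "the series" means these few. Any claim that something is new, unique, unknown or untested is made for them only; others in the source may bear on it.

Working notes on the amides built on the shared core of compound 1 (`CCN1CCN(c2cc(C)c3cc(NC(=O)c4ccc[nH]4)ccc3n2)CC1`). In a functional assay on SK-BR-3 cells (Homo sapiens) for antiproliferative activity, read by MTT assay, with a stated time of 72 h (a lower number here means a stronger inhibitor, a higher number a weaker inhibitor), compound 1 gives 13200 nM, compound 2 (`CCN1CCN(c2cc(C)c3cc(NC(=O)c4ccccc4C)ccc3n2)CC1`) gives 29200 nM and compound 3 (`CCN1CCN(c2cc(C)c3cc(NC(=O)c4cc(Cl)cc(Cl)c4)ccc3n2)CC1`) gives 2660 nM. Compound 3 therefore has the lowest number of the three, and its gaps to both others lie beyond the scatter.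

The next structure is compound 4 (`CCN1CCN(c2cc(C)c3cc(NC(=O)c4ccccc4Cl)ccc3n2)CC1`), with 2-chlorophenyl in place of 3,5-dichlorophenyl on a carbonyl carbon.

The measured step closest to this change is an 11-fold lower number from compound 2 to compound 3 (1.04 log units; beyond the scatter), where 3,5-dichlorophenyl replaces 2-methylphenyl. Its size is large, and compound 4 would run it largely in reverse. The other two steps, a 5.0-fold lower number from compound 1 to compound 3 (0.70 log units; beyond the scatter) and a 2.2-fold higher number from compound 1 to compound 2 (0.34 log units; beyond the scatter), show that the group on the carbonyl carbon moves the number in either direction in this assay. For the measured compounds named here, no measured compound carries 2-chlorophenyl, so the exchange of 2-methylphenyl for 2-chlorophenyl remains untested.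

Compound 2, at 29200 nM, is the closest reference for compound 4, and a higher number than compound 3 is expected, somewhat short of the full reversal. The expected change is a 6.0-fold higher number from compound 3 to compound 4 (0.78 log units; beyond the scatter). For compound 4 the estimated value is 16000 nM, with an expected range of 7000 nM to 35000 nM.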

Compound 4, half-maximal inhibitory concentration: > 50000 nM
Compound 4: a limit, no number; the forecaster's own chance of this, stated with the estimate: 5%; middle value at least 3.1-fold (0.49 log units) from the limit.
By their numbers in this assay, from the lowest: compound 3; then compound 1; then compound 2. At a limit, above all of these: compound 4.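

In this assay compound 4 gives a limit and not a number, so every step reaching it is a floor: the limit of > 50000 nM in this assay, at which 1 of the 4 values shown sits. Moving from 3,5-dichlorophenyl to 2-chlorophenyl on a carbonyl carbon gives an at least 18-fold higher number from compound 3 to compound 4 (1.27 log units; beyond the scatter), so a chloro group on the phenyl ring does not by itself bring the low number of compound 3. The exchange of chloro for methyl on an aromatic carbon gives an at least 1.7-fold higher number from compound 2 to compound 4 (0.23 log units; that floor lies within the scatter), which leaves its size unsettled, while an at least 3.7-fold higher number from compound 1 to compound 4 (0.57 log units; beyond the scatter) puts 2-chlorophenyl, like 2-methylphenyl, on the higher side of 1H-pyrrol-2-yl, with compound 3 the one phenyl amide here that goes against this.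

From the compounds shown here alone, how far the true value of compound 4 lies past its limit stays open, and with it whether 2-chlorophenyl and 2-methylphenyl really differ. Also open, going by these compounds, is how plain phenyl, or a phenyl ring carrying an amine or a carboxylic acid, would behave on the same carbonyl carbon, which would help show what sets compound 3 apart.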